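The source may hold more compounds than are shown below. What is called first, only, known or untested is meant among the compounds shown, and "the series" means these compounds.

Within the data shown here, in a functional assay on HepG2 cells (Homo sapiens) for antiproliferative activity, read by MTT assay, with a stated time of 24 h (a higher number here means a weaker inhibitor, a lower number a stronger inhibitor), compound 3 (`Cc1ccc(-c2nn(-c3ccccc3)cc2-c2nc3ccccc3n2S(=O)(=O)c2ccc(F)cc2)cc1`) gives 5060 nM, the highest number of the three measured so far, with compound 1 (`Cc1ccc(-c2nn(-c3ccccc3)cc2-c2nc3ccccc3n2S(=O)(=O)c2ccccc2)cc1`) at 960 nM and compound 2 (`Cc1ccc(-c2nn(-c3ccccc3)cc2-c2nc3ccccc3n2S(=O)(=O)c2cc(C)ccc2C)cc1`) at 460 nM. Compound 4 (`Cc1ccc(-c2nn(-c3ccccc3)cc2-c2nc3ccccc3n2S(=O)(=O)c2ccc(Br)cc2)cc1`) has bromo in place of fluoro on an aromatic carbon, para to a large group: bromo in place of fluoro on an aromatic carbon. Among the measured compounds shown here, no measured step exchanges one halogen for another, so the evidence is indirect. The closest step is a 5.3-fold higher number from compound 1 to compound 3 (0.72 log units; beyond the scatter), where fluoro replaced hydrogen at this place. The step of an 11-fold higher number from compound 2 to compound 3 (1.04 log units; beyond the scatter) shows how far a change of the group on the sulfonyl sulfur can move the number, while a 2.1-fold lower number from compound 1 to compound 2 (0.32 log units; beyond the scatter) shows that a substituted ring need not raise it. The high number of compound 3 may therefore belong to fluoro, and a partial return towards compound 1 is expected in this assay. The expected change is a 2.3-fold lower number from compound 3 to compound 4 (0.36 log units; beyond the scatter), a modest step to a lower number, though the uncertainty is wide. For compound 4 the estimate is 2200 nM, with an expected range from 700 nM to 6500 nM.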

Compound 4, half-maximal inhibitory concentration: 3040 nM
Compound 4: the middle estimate sits 1.4-fold (0.14 log units) below what was measured; the range from low to high includes it.
By their numbers in this assay, from the lowest: compound 2; then compound 1; then compounds 4 and 3 (each within the scatter of the next).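

In this assay, bromo in place of fluoro on an aromatic carbon, para to a large group, is a step within the scatter (a 1.7-fold lower number from compound 3 to compound 4 (0.22 log units; within the scatter)), so this exchange does not separate the two halogens. Bromo in place of hydrogen at the same place still gives a step beyond the scatter (a 3.2-fold higher number from compound 1 to compound 4 (0.50 log units; beyond the scatter)), so the higher number is not confined to fluoro: in this small set, both halogens go the same way against the unsubstituted phenyl of compound 1. The 4-bromophenyl group also stays well apart from the 2,5-dimethylphenyl group (a 6.6-fold higher number from compound 2 to compound 4 (0.82 log units; beyond the scatter)), and no measured evidence accounts for any of these steps.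

On these data alone, whether a methoxy group or an amine at this place would track the halogens or hydrogen remains open. Also open, as far as these compounds go, is whether the lower number of compound 2 requires both methyl groups or follows from one alone.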